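The compounds below may be only part of what the source reports. "The series", "measured", "known", "first", "only" and "open" are said of these compounds alone.

Compound 1 `CC(C)C(c1noc(=O)[nH]1)c1ccc(-c2ccc3cccc(F)c3c2)[nH]c1=O` stands in an ADME assay on microsomes from liver (Homo sapiens) for metabolic stability (a higher number here means that the compound lasts longer, a lower number that the compound disappears faster), only at a boundary: its half-life of > 3 h is a limit of the assay, not a number, as noted by the limit of > 3 h in this assay, at which 1 of the 3 values shown sits. The two companions give numbers. Compound 2 `CCn1ncc2c(F)cc(-c3ccc(C(CC)(CC)c4nncn4C)c(=O)[nH]3)cc21` shows a half-life of 2.67 h in this assay, and compound 3 `CCC(CC)(c1nnc[nH]1)c1ccc(-c2ccc3cc(F)cc(F)c3c2)[nH]c1=O` shows 1.76 h, the two lying within the usual scatter of each other. Compound 4 `CC(C)C(Cc1noc(=O)[nH]1)c1ccc(-c2ccc3cccc(F)c3c2)[nH]c1=O` differs from compound 1 by a group of 7 heavy atoms (3 carbon, 2 nitrogen, 2 oxygen; one five-membered aromatic ring with 3 hetero atoms) in place of a group of 6 heavy atoms (2 carbon, 2 nitrogen, 2 oxygen; one five-membered aromatic ring with 3 hetero atoms), on a saturated chain carbon bound to an aromatic carbon and a saturated chain carbon. Among the measured compounds shown here, no measured step connects any pair here, so the expected step from compound 1 to compound 4 in this assay is estimated as small, an at least 1.2-fold lower number from compound 1 to compound 4 (0.07 log units; that floor lies within the scatter), and not clearly beyond the scatter. Compound 4 is expected to reach about 2.5 h, within 1.2 h to 5 h.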

Compound 4, half-life: > 3 h
Compound 4 gave a limit, no number; the forecaster's own chance of this, stated with the estimate: 40%; middle value at least 1.2-fold (0.07 log units) away from the limit.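

Compound 1 and compound 4 both stand at a limit in this assay, not at a number, so no step between them can be read: the limit of > 3 h in this assay, at which 2 of the 4 values shown sit.

The compounds shown leave open what half-life either compound has, and whether the group of 7 heavy atoms differs in effect from the group of 6 heavy atoms.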